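This account rests on a few compounds, and the source may have more. Where it says the series, first, only, none or still open, it means among the compounds named here.

Measured so far:
compound 1, `CC(=O)Nc1cccc2c1CCCC2c1c[nH]cn1` — 525 nM
compound 2, `CCS(=O)(=O)Nc1cccc2c1CCCC2c1c[nH]c(C)n1` — 794 nM
compound 3, `CS(=O)(=O)Nc1cccc2c1CCCC2C1=NCCN1` — 457 nM

All three were tested in an assay on isolated protein for binding affinity to Alpha-1A adrenergic receptor (Rattus norvegicus), read by radioligand binding; on this read-out higher numbers stand for weaker inhibition and lower numbers for stronger inhibition. The three numbers sit close together: compound 3 gives 457 nM, and its gaps to compound 1 and to compound 2 both fall within the usual scatter of repeated measurements, so no real difference among them can be claimed on this read-out.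

The next compound, compound 4 `Cn1cncc1C1CCCc2c(NS(C)(=O)=O)cccc21`, has not yet been measured in this assay. It differs from compound 3 in one place: a group of 6 heavy atoms (4 carbon, 2 nitrogen; one five-membered aromatic ring with 2 hetero atoms) in place of a group of 5 heavy atoms (3 carbon, 2 nitrogen; one five-membered non-aromatic ring with 2 hetero atoms), on a saturated ring carbon. The group that leaves carries one hydrogen-bond donor; the group that enters carries none, and it is aromatic where the leaving group is not.

Going by the values given here, no measured pair shows what such a swap does, so the size of the step is open. Compound 1 carries an aromatic ring of this kind and its value of 525 nM lies close to compound 3, which suggests the aromatic ring as such is tolerated; the loss of the hydrogen-bond donor is the unknown part. A modest weakening, larger than the scatter but not dramatic, is expected for compound 4, an estimated step of a 3.3-fold higher number from compound 3 to compound 4 (0.52 log units; beyond the scatter). Compound 4 is therefore estimated at 1500 nM, with a plausible range from 400 nM to 6000 nM.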

Compound 4, inhibition constant: < 10000 nM
Compound 4: a limit, no number; the forecaster's own chance of this, stated with the estimate: 10%; the middle value lies beyond the limit too.
By their numbers in this assay, from the lowest: compounds 3, 1 and 2 (each within the scatter of the next).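

In this assay compound 4 gives < 10000 nM, which is a limit of the assay and not a number. The step from compound 3 to compound 4 therefore cannot be read. The compounds shown leave open whether the 1-methyl-1H-imidazol-5-yl group of compound 4 changes the value seen with compound 3 at all, and by how much.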